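Chloro for fluoro on the aromatic carbon

This account rests on a few compounds, and the source may have more. Where it says the series, first, only, none or still open, it means among the compounds named here.

Compound 1 `COc1cc(NC(C)CCCNC(=O)Nc2ccc(F)cc2)c2ncccc2c1` gives 24000 nM in a functional assay on MOLT-4 cells (Homo sapiens) for inhibition, read by MTT assay, with a stated time of 72 h; on this read-out higher numbers stand for weaker inhibition and lower numbers for stronger inhibition. Compound 2 `COc1cc(NC(C)CCCNC(=O)Nc2ccc(O)cc2)c2ncccc2c1` gives 21000 nM in this assay, and compound 3 `COc1cc(NC(C)CCCNC(=O)Nc2cccc(C(F)(F)F)c2)c2ncccc2c1` gives 20000 nM. Compound 1 carries the highest of the three numbers, yet the step of a 1.1-fold lower number from compound 1 to compound 2 (0.06 log units; within the scatter) and the step of a 1.2-fold lower number from compound 1 to compound 3 (0.08 log units; within the scatter) both stay within the scatter, as does a 1.1-fold lower number from compound 2 to compound 3 (0.02 log units; within the scatter), so the three compounds stand level on this read-out.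

Compound 4 `COc1cc(NC(C)CCCNC(=O)Nc2ccc(Cl)cc2)c2ncccc2c1` has not been measured. It differs from compound 1 by chloro in place of fluoro on an aromatic carbon. The two measured steps from compound 1 bear on this change, since each alters the same 4-fluorophenyl group that carries the fluoro, one to 4-hydroxyphenyl and one to 3-(trifluoromethyl)phenyl, and neither moved the number beyond the scatter. The step of a 1.1-fold lower number from compound 1 to compound 4 (0.04 log units; within the scatter) is therefore expected to stay within the scatter, in no particular direction. Compound 4 is estimated at 22000 nM in this assay, with a range from 11000 nM to 44000 nM.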

Compound 4, half-maximal inhibitory concentration: 24000 nM
For compound 4 the middle estimate is 1.1-fold (0.04 log units) below the measured one, within the range that was stated.
By their numbers in this assay, from the lowest: compounds 3, 2, 1 and 4 (each within the scatter of the next).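

Chloro in place of fluoro on the aromatic carbon para to a large group leaves the number in this assay unmoved, with no change at the digits printed from compound 1 to compound 4 (within the scatter). Compound 4 also stands level with the other two compounds, with a 1.1-fold higher number from compound 2 to compound 4 (0.06 log units; within the scatter) and a 1.2-fold higher number from compound 3 to compound 4 (0.08 log units; within the scatter), so a second halogen at this place joins hydroxy and the shifted trifluoromethyl group in giving no step beyond the scatter. No data shown here bear on why this read-out stays flat across the four compounds.

From the compounds shown here alone, whether an amine or a carboxylic acid on this aromatic ring would give a step beyond the scatter remains open. So does the effect of a longer chain, since the shared core and its chain stay the same in all four compounds.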